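The source may hold more compounds than are shown below. What is called first, only, known or untested is meant among the compounds shown, and "the series" means these compounds.

Measured compounds:
- compound 1, `CCC(/C=C(\COC(=O)c1ccccc1)C(=O)c1ccc(OC)cc1)CC`, in a functional assay on MCF7 cells (Homo sapiens) for inhibition, read by XTT assay, with a stated time of 48 h (a higher number here means a weaker inhibitor, a lower number a stronger inhibitor), gives 28000 nM
- compound 2, `COc1ccc(C(=O)/C(=C/c2ccc(Cl)cc2Cl)CCOC(C)=O)cc1`, in this assay gives 83400 nM

Compound 2 has the higher of the two numbers, and its gap to compound 1 is beyond the usual scatter. Compound 3, `CCC(/C=C(\CCOC(C)=O)C(=O)c1ccc(OC)cc1)CC`, is not yet measured. It differs from compound 2 by one change: pentan-3-yl in place of 2,4-dichlorophenyl on a double-bonded chain carbon bound to a double-bonded chain carbon. Compound 1 also carries pentan-3-yl, yet it differs from compound 3 in a second place, so its value alone cannot fix the size of this change. For compound 3 a modest downward step, a 1.9-fold lower number from compound 2 to compound 3 (0.27 log units; within the scatter), is expected, close to the scatter. Compound 3 is estimated at 45000 nM, within 15000 nM to 130000 nM.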

Compound 3, half-maximal inhibitory concentration: > 100000 nM
Compound 3: no number, only a limit; the forecaster's own chance of this, stated with the estimate: 10%; middle value at least 2.2-fold (0.34 log units) away from the limit.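

In this assay compound 3 gives > 100000 nM, which is a limit of the assay and not a number. Pentan-3-yl in place of 2,4-dichlorophenyl gives an at least 1.1-fold higher number from compound 2 to compound 3 (0.07 log units; that floor lies within the scatter), so this change brings no gain in strength here. Acetoxymethyl in place of benzoyloxy gives an at least 3.5-fold higher number from compound 1 to compound 3 (0.55 log units; beyond the scatter), so with pentan-3-yl kept, that ester change clearly weakens inhibition, though both steps are floors and not full sizes: the limit of > 100000 nM in this assay, at which 1 of the 3 values shown sits.

Going by these compounds, whether an amine or a carboxylic acid in place of pentan-3-yl would give a lower number stays open. So does how 2,4-dichlorophenyl would behave alongside benzoyloxy.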